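A few compounds are considered here, and "the series" means these few. Any claim that something is new, unique, unknown or untested is made for them only; others in the source may bear on it.

Measured compounds in a functional assay on MDA-MB-231 cells (Homo sapiens) for inhibition, read by MTT assay, with a stated time of 24 h; on this read-out lower numbers stand for stronger inhibition and higher numbers for weaker inhibition:

compound 1 `CCc1cc2ccccc2nc1-c1cc(-c2ccccc2)no1` gives > 100000 nM, a limit of the assay.
compound 2 `CCc1cc2ccccc2nc1-c1cc(-c2ccc(F)cc2)no1` gives > 100000 nM, a limit of the assay.
compound 3 `CCc1cc2ccccc2nc1-c1cc(-c2ccc(C)cc2)no1` gives > 100000 nM, a limit of the assay.

Where compound 3 stands: only a limit is known for it in this assay, and the two other values recorded for the series are limits as well, all of them sitting at the limit of > 100000 nM in this assay, at which 3 of the 3 values shown sit. No ordering of the three compounds is therefore possible on the numbers shown.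

The measured steps give no readable size. The change from compound 1 to compound 2 , a step that the two limits leave unreadable from compound 1 to compound 2, from compound 1 to compound 3 , a step that the two limits leave unreadable from compound 1 to compound 3, and from compound 2 to compound 3 , a step that the two limits leave unreadable from compound 2 to compound 3, all run between limits and remain unreadable in this assay.

Compound 4 `CCc1cc2ccccc2nc1-c1cc(-c2ccc(C(F)(F)F)cc2)no1` carries the change (trifluoromethyl in place of methyl on an aromatic carbon), that is, trifluoromethyl in place of methyl on an aromatic carbon, para to a large group. None of the three measured steps bears readably on it, and every comparable substitution at this position has left the value at the limit. The expectation for compound 4 is therefore no readable step, a step that the limit leaves unreadable from compound 3 to compound 4, beyond the scatter. Compound 4 is estimated at 150000 nM, with a range from 30000 nM to 1000000 nM, most likely reported again only as a limit.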

Compound 4, half-maximal inhibitory concentration: > 100000 nM
Compound 4: only a limit was reported; the forecaster's own chance of this, stated with the estimate: 80%; the middle value does not contradict the limit.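

Compound 4 is reported only as a limit in this assay, as are compound 1, compound 2 and compound 3, so no step among these compounds can be read: the limit of > 100000 nM in this assay, at which 4 of the 4 values shown sit.

The compounds shown leave open how the four compounds rank and whether any group on this aromatic carbon can bring a value within the readable range of this assay.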